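A Propyl for a Phenyl at the Amide Terminus

The source may report more compounds than this note shows. Statements on the series, on what has been measured and on what is new or still open speak of the compounds shown alone.

Compound 1 `COc1ccccc1C(=O)Nc1cccc(-c2oc3cc(-c4ccc(F)cc4)ccc3c(=O)c2O)c1` and compound 2 `O=C(Nc1cccc(-c2oc3cc(-c4ccc(F)cc4)ccc3c(=O)c2O)c1)c1ccc(-c2ccccc2)cc1` share one core and differ only in the group on the carbonyl carbon. In a functional assay on HCC1937 cells (Homo sapiens) for antiproliferative activity, read by CCK-8 assay, with a stated time of 72 h (on this read-out lower numbers stand for stronger inhibition and higher numbers for weaker inhibition), compound 1 gives 9050 nM, while compound 2 gives 44100 nM, the higher of the two numbers, after a step of a 4.9-fold higher number from compound 1 to compound 2 (0.69 log units; beyond the scatter). Compound 3 `CCCc1ccc(C(=O)Nc2cccc(-c3oc4cc(-c5ccc(F)cc5)ccc4c(=O)c3O)c2)cc1` differs from compound 2 by propyl in place of phenyl on an aromatic carbon, so 4-phenylphenyl becomes 4-propylphenyl. Within the data shown here, only that one measured step bears on this change, and it was modest, so a modest move toward a lower number is expected, a 2.0-fold lower number from compound 2 to compound 3 (0.30 log units; within the scatter). Compound 3 is therefore expected to give 22000 nM, between 9000 nM and 55000 nM.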

Compound 3, half-maximal inhibitory concentration: 15400 nM
For compound 3 the middle estimate is 1.4-fold (0.15 log units) above the measured one; measured number inside the range.
By their numbers in this assay, from the lowest: compounds 1 and 3 (each within the scatter of the next); then compound 2.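

In this assay, the outer phenyl ring is not required at this position: propyl in its place gives a 2.9-fold lower number from compound 2 to compound 3 (0.46 log units; beyond the scatter), so a chain without a ring gives a lower number here than 4-phenylphenyl does. Set against the 2-methoxyphenyl group, 4-propylphenyl gives a 1.7-fold higher number from compound 1 to compound 3 (0.23 log units; within the scatter), leaving these two groups level. Nothing measured here accounts for either step. On these data alone, it remains open whether a longer chain such as butyl, or an amine or a carboxylic acid in place of propyl, would lower the number further. The compounds shown also leave open whether any group at this position can go beyond the level of compound 1 and compound 3.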